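The source may hold more compounds than are shown below. What is called first, only, known or untested is meant among the compounds shown, and "the series" means these compounds.

In a functional assay on HeLa cells (Homo sapiens) for cytotoxicity, read by MTT assay, with a stated time of 72 h (on this read-out higher numbers stand for weaker inhibition and lower numbers for stronger inhibition), the measured compounds stand as follows:
compound 1 `Cc1cc(-c2ccccc2)n(/C(N)=N/S(=O)(=O)c2cc(C)c(Cl)cc2SCc2cccc(C(F)(F)F)c2)n1` gives 98000 nM;
compound 2 `Cc1cc(S(=O)(=O)/N=C(\N)n2nccc2-c2ccccc2)c(SCc2cccc(C(F)(F)F)c2)cc1Cl` gives 19000 nM;
compound 3 `Cc1ccc(CSc2cc(Cl)c(C)cc2S(=O)(=O)/N=C(\N)n2nccc2-c2ccccc2)cc1` gives 17000 nM.

Compound 1 thus has the highest number of the three, with a 5.2-fold lower number from compound 1 to compound 2 (0.71 log units; beyond the scatter) and a comparable gap to compound 3. Compound 4 `Cc1cc(-c2ccccc2)n(/C(N)=N/S(=O)(=O)c2cc(C)c(Cl)cc2SCc2ccccc2Cl)n1` differs from compound 1 in one place: 2-chlorophenyl in place of 3-(trifluoromethyl)phenyl on a saturated chain carbon bound to a sulfur. Among the compounds with values here, the only measured step at the same place is a 1.1-fold lower number from compound 2 to compound 3 (0.05 log units; within the scatter), which stayed within the scatter. On that basis no step beyond the scatter is expected in this assay from compound 1 to compound 4, and the estimated change is a 1.1-fold lower number from compound 1 to compound 4 (0.04 log units; within the scatter). Compound 4 is therefore expected to give about 90000 nM, within a range from 30000 nM to 250000 nM.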

Compound 4, half-maximal inhibitory concentration: 270000 nM
Beside the measured number, compound 4's estimate is 3.0-fold (0.48 log units) below it; the measured number lies above the stated range.
By their numbers in this assay, from the lowest: compounds 3 and 2 (each within the scatter of the next); then compound 1; then compound 4.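

In this assay, the group on the saturated chain carbon bound to a sulfur can move the number beyond the scatter, with a 2.8-fold higher number from compound 1 to compound 4 (0.44 log units; beyond the scatter), whereas the earlier change at this place, a 1.1-fold lower number from compound 2 to compound 3 (0.05 log units; within the scatter), did not. That earlier change involved a different incoming group and a core with hydrogen in place of methyl, so the two steps do not show which difference matters. No measurement at hand accounts for the new step. From the compounds shown here alone, whether 2-chlorophenyl would raise the number on the core of compound 2 remains open. So does the effect of an amine or carboxylic acid on this phenyl ring, or of a longer chain before it.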